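The source may report more compounds than this note shows. Statements on the series, on what has been measured and on what is new or still open speak of the compounds shown alone.

Measured compounds:
compound 1, `COc1cc(-c2cc(/C=C/C(=O)c3ccc(N)cc3)[nH]n2)cc(OC)c1OC`: 99%
compound 2, `COc1cc(-c2cc(/C=C/C(=O)c3ccc(Cl)c(Cl)c3)[nH]n2)cc(OC)c1OC`: 92%

In a functional assay on SF-268 cells (Homo sapiens) for cytotoxicity, read by sulforhodamine B assay, with a stated time of 48 h, tested at 0.01 uM (a higher number here means a weaker effect of the compound at the concentration tested, a lower number a stronger effect), compound 1 gives 99% and compound 2 gives 92%. Among the compounds with values here, both numbers lie high, so at the concentration tested each shows only a weak effect, and compound 2 sits within the scatter of compound 1: the step of a number 7 percentage points lower from compound 1 to compound 2 (within the scatter) is the only measured comparison.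

Compound 3, `COc1ccc(C(=O)/C=C/c2cc(-c3cc(OC)c(OC)c(OC)c3)n[nH]2)cc1OC`, is not yet measured. It differs from compound 2 only in one place: 3,4-dimethoxyphenyl in place of 3,4-dichlorophenyl on a carbonyl carbon. Within the data shown here, the one step available, a number 7 percentage points lower from compound 1 to compound 2 (within the scatter), also exchanged the group on that carbonyl carbon and stayed within the scatter, so a change of the same kind at the same place gives no ground to expect a step beyond the scatter in this assay for compound 3; the data hold nothing specific on a 3,4-dimethoxyphenyl group.

The expected step from compound 2 is therefore a number 3 percentage points higher from compound 2 to compound 3 (within the scatter), essentially none beyond the scatter. In this assay compound 3 is estimated at 95%, with a range from 82% to 105%.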

Compound 3, a percentage reported as activity, at one concentration (the size of the read-out at that concentration, not a potency): 93%
Compound 3: the middle estimate sits 2 percentage points above what was measured; the range from low to high includes it.
By their numbers in this assay, from the lowest: compounds 2, 3 and 1 (each within the scatter of the next).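

On the carbonyl carbon, a third group now stands in the series: in this assay, exchanging 3,4-dichlorophenyl for 3,4-dimethoxyphenyl gives a number 1 percentage points higher from compound 2 to compound 3 (within the scatter) and exchanging 4-aminophenyl for 3,4-dimethoxyphenyl gives a number 6 percentage points lower from compound 1 to compound 3 (within the scatter) as the comparison with the remaining group. The earlier pair covered only a chlorine-bearing and an amine-bearing ring, whereas this change brings in a larger group of 10 heavy atoms with 2 hydrogen-bond acceptors, and the read-out at this position still stays within the scatter across all three compounds. No independent measurement bears on this result, so the data give no account of it.

All three compounds show only a weak effect at the single concentration shown, so this read-out cannot tell whether these groups would separate at higher concentrations. Also open, from the compounds shown here alone, is whether the insensitivity extends beyond substituted phenyl rings on the carbonyl carbon, for instance to a pyridine, a thiophene or a simple methyl group, or to a phenyl ring carrying a carboxylic acid.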